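From a methoxy group to a 4-methoxyphenoxy group

This account rests on a few compounds, and the source may have more. Where it says the series, first, only, none or still open, it means among the compounds named here.

compound 1 `Nc1ccccc1NC(=O)C1(S(=O)(=O)c2ccc(Oc3ccc(OC(F)(F)F)cc3)c(Cl)c2)CCC2(CCNCC2)C1` gives 3700 nM
compound 2 `COc1ccc(S(=O)(=O)C2(C(=O)Nc3ccccc3N)CCC3(CCNCC3)C2)cc1Cl` gives 7500 nM

Compound 2 has the higher of the two numbers in a functional assay on blood (Homo sapiens), with a stated time of 60 min, in the presence of a further agent that is not named here (a higher number here means that more compound is needed for the effect, a lower number that less compound is needed), with 7500 nM as its value. Compound 3 `COc1ccc(Oc2ccc(S(=O)(=O)C3(C(=O)Nc4ccccc4N)CCC4(CCNCC4)C3)cc2Cl)cc1` carries 4-methoxyphenyl in place of methyl on an oxygen on an aromatic ring. Among the compounds with values here, the one measured step bearing on this is a 2.0-fold higher number from compound 1 to compound 2 (0.31 log units; beyond the scatter) and it is modest, though beyond the scatter, with methyl in place of 4-(trifluoromethoxy)phenyl. Compound 1 at 3700 nM is the nearest guide, so a modest move to a lower number is expected. The estimated step reads a 2.0-fold lower number from compound 2 to compound 3 (0.30 log units; within the scatter) for this change. Compound 3 is estimated at 3800 nM with an expected range of 1700 nM to 8000 nM in this measurement.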

Compound 3, half-maximal effective concentration: > 15000 nM
Compound 3: no number, only a limit; the forecaster's own chance of this, stated with the estimate: 3%; middle value at least 3.9-fold (0.59 log units) from the limit.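

Compound 3 in this assay yields only a limit, not a number: the limit of > 15000 nM in this assay, at which 1 of the 3 values shown sits. With methyl in place of trifluoromethyl on an oxygen on an aromatic ring, the change reads an at least 4.0-fold higher number from compound 1 to compound 3 (0.60 log units; beyond the scatter), so a change on the far end of the aryl ether alone moves the result beyond the scatter, which the earlier pair did not show. The step for 4-methoxyphenyl in place of methyl reads an at least 2.0-fold higher number from compound 2 to compound 3 (0.30 log units; that floor lies within the scatter), and that floor alone does not separate the two compounds.

On these data alone, how far compound 3 lies past its limit remains open. So does what an amine or a carboxylic acid in place of the methoxy group on that ring would give.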